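Ethoxy to methylsulfanyl on the shared core

The source may hold more compounds than are shown below. What is called first, only, known or untested is meant among the compounds shown, and "the series" means these compounds.

Measured so far, in a functional assay on the whole organism with Rattus norvegicus as the target, with a stated time of 4 h, at a dose of 40 mg/kg by the intraperitoneal route; a higher number here means more inhibition at the dose given (going by the name of the read-out), a lower number less inhibition:
Compound 1, `Cc1cn2cccc(OCc3ccccc3)c2n1`, gives 62%.
Compound 2, `Cc1nc2c(OCc3ccccc3)cccn2c1C#N`, gives 25%.
Compound 3, `CCOCc1c(C)nc2c(OCc3ccccc3)cccn12`, gives 84%.

Compound 3 stands highest of the three numbers; the steps to compound 1 and to compound 2 are both beyond the scatter, so its number is the highest of the measured set in this assay. Compound 4, `CSCc1c(C)nc2c(OCc3ccccc3)cccn12`, differs from compound 3 in one place: methylsulfanyl in place of ethoxy on a saturated chain carbon bound to an aromatic carbon.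

Within the data shown here, no measured step changes the ethoxy itself. The two steps that end at compound 3 are a number 22 percentage points higher from compound 1 to compound 3 (beyond the scatter) and a number 59 percentage points higher from compound 2 to compound 3 (beyond the scatter); both concern what sits on the aromatic carbon, not the swap within the chain. They show that the substituent at this carbon matters, but give no direction for ethoxy against methylsulfanyl. The expectation is therefore a step of a number 9 percentage points lower from compound 3 to compound 4 (within the scatter), around or within the scatter, with more room downward than upward since compound 3 already stands high. Compound 4 is estimated at 75%, expected between 55% and 90%.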

Compound 4, a percentage reported as inhibition, in the whole organism at one dose (the size of the read-out at that dose, not a potency): 29%
Compound 4: middle estimate off by 46 percentage points, on the high side, outside the stated range (below it).
By their numbers in this assay, from the lowest: compounds 2 and 4 (each within the scatter of the next); then compound 1; then compound 3.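

In this assay the saturated chain carbon bound to an aromatic carbon proves sensitive to what it carries: methylsulfanyl in place of ethoxy gives a number 55 percentage points lower from compound 3 to compound 4 (beyond the scatter). The gain of ethoxymethyl over hydrogen, a number 22 percentage points higher from compound 1 to compound 3 (beyond the scatter), therefore does not extend to (methylsulfanyl)methyl, which gives a number 33 percentage points lower from compound 1 to compound 4 (beyond the scatter) and, against cyano, a number 4 percentage points higher from compound 2 to compound 4 (within the scatter), so substitution on this aromatic carbon can raise or lower the number depending on the group. Nothing available bears on why this single exchange has so large an effect.

The compounds shown do not separate the sulfur from the heavy-atom count, since the two change together in this step. Going by these compounds, how methoxy or an amine on the same chain carbon would read in this assay stays open.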